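Changing the Group on the Ring Nitrogen: Compound 4

The compounds below may be only part of what the source reports. "The series", "measured", "known", "first", "only" and "open" are said of these compounds alone.

The three measured compounds are:
compound 1, `Cc1nc(-c2ccccc2F)c(C(=O)N2CCN(c3cc(Cl)cc(Cl)c3)CC2)o1`: 60.2 nM
compound 2, `Cc1nc(-c2ccccc2)c(C(=O)N2CCN(c3ccc(C(F)(F)F)cc3)CC2)o1`: > 1000 nM
compound 3, `Cc1ccc(N2CCN(C(=O)c3oc(C)nc3-c3ccccc3)CC2)c(C)c1`: 101 nM

In a functional assay on HL-60 cells (Homo sapiens) for inhibition, read by MTT assay, with a stated time of 72 h (a higher number here means a weaker inhibitor, a lower number a stronger inhibitor), compound 1 gives 60.2 nM and compound 3 gives 101 nM; these two numbers lie within the scatter of each other, so neither can be called the stronger. For compound 2 the assay reports only a limit, > 1000 nM, not a number. Compound 3 therefore stands alongside compound 1, with the limit of compound 2 as the only other entry.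

Compound 4, `Cc1nc(-c2ccccc2)c(C(=O)N2CCN(c3cccc(F)c3)CC2)o1`, differs from compound 3 in one place: 3-fluorophenyl in place of 2,4-dimethylphenyl on an amine nitrogen in a ring. Going by the values given here, only one measured step changes the same position, and it is large: an at least 9.9-fold lower number from compound 2 to compound 3 (0.99 log units; beyond the scatter), though its size is bounded because of the limit of > 1000 nM in this assay, at which 1 of the 3 values shown sits. That step shows the aryl group on the ring nitrogen can matter a great deal, but it does not involve 3-fluorophenyl. Compound 1, which carries a halogen-bearing aryl group at the same place, gives 60.2 nM, so a halogen there is compatible with a low number.

Compound 4 is expected to give 150 nM in this assay, within 50 nM to 600 nM. The expected step is a 1.5-fold higher number from compound 3 to compound 4 (0.17 log units; within the scatter), close to the scatter.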

Compound 4, half-maximal inhibitory concentration: 45 nM
Beside the measured number, compound 4's estimate is 3.3-fold (0.52 log units) above it, and the stated range ends above it.
By their numbers in this assay, from the lowest: compounds 4, 1 and 3 (each within the scatter of the next, the first and the last beyond it). At a limit, above all of these: compound 2.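

In this assay, putting 3-fluorophenyl in place of 2,4-dimethylphenyl on the amine nitrogen in the ring gives a 2.2-fold lower number from compound 3 to compound 4 (0.35 log units; beyond the scatter), a modest step but one beyond the scatter. The two groups match in what is counted for them, each having one six-membered aromatic ring of carbon only, no hydrogen-bond donors or acceptors and no net charge, so the number at this position can shift between aryl groups that those counts do not tell apart. Going from 4-(trifluoromethyl)phenyl to 3-fluorophenyl at the same place gives a larger step, an at least 22-fold lower number from compound 2 to compound 4 (1.34 log units; beyond the scatter), and its full size stays unknown because compound 2 has only a limit: the limit of > 1000 nM in this assay, at which 1 of the 4 values shown sits.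

Still open, from the compounds shown here alone, is whether 3-fluorophenyl owes its number to the fluorine itself or to where the fluorine sits on the phenyl ring. Also open, going by these compounds, is how the number would respond to a different kind of group at this nitrogen, such as a cyclohexyl ring, or to a phenyl ring carrying an amine or a carboxylic acid.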